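This account rests on a few compounds, and the source may have more. Where it says the series, first, only, none or still open, it means among the compounds named here.

In a functional assay (lung) for inhibition, with Cavia porcellus as the target (on this read-out lower numbers stand for stronger inhibition and higher numbers for weaker inhibition), compound 1 `c1cc(OCCCc2nnn[nH]2)cc(OCc2ccc3ccccc3n2)c1` gives 79 nM and compound 2 `CC(CCCc1cccc(OCc2ccc3ccccc3n2)c1)C(=O)O` gives 75 nM, so compound 2 stands level with compound 1 within the scatter. Compound 3 `CC(CCc1nnn[nH]1)Cc1cccc(OCc2ccc3ccccc3n2)c1` differs from compound 2 in one place, on a saturated chain carbon bound to an aromatic carbon: 3-(1H-tetrazol-5-yl)-1-methylpropyl in place of 3-carboxybutyl on a saturated chain carbon bound to an aromatic carbon. Among the measured compounds shown here, the one measured step that bears on this, a 1.1-fold lower number from compound 1 to compound 2 (0.02 log units; within the scatter), also exchanges a tetrazolyl chain and a carboxy chain, and it stays within the scatter. In this assay no step beyond the scatter is therefore expected, and the estimated step is a 1.1-fold lower number from compound 2 to compound 3 (0.03 log units; within the scatter). The estimate for compound 3 is 70 nM, with an expected range of 25 nM to 200 nM.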

Compound 3, half-maximal inhibitory concentration: 150 nM
For compound 3 the middle estimate is 2.1-fold (0.33 log units) below the measured one; low and high end bracket the measured number.
By their numbers in this assay, from the lowest: compounds 2, 1 and 3 (each within the scatter of the next).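

In this assay the exchange of 3-carboxybutyl for 3-(1H-tetrazol-5-yl)-1-methylpropyl gives a 2.0-fold higher number from compound 2 to compound 3 (0.30 log units; within the scatter) at this place on a saturated chain carbon bound to an aromatic carbon. The position therefore takes the larger group, with its five-membered aromatic ring and 9 heavy atoms instead of 7, with no step beyond the scatter. Together with the earlier step, this puts all three compounds within the scatter of their neighbours on this read-out. The compounds shown leave open how an amine or a longer chain carrying the carboxylic acid would read at this place. Nothing available here explains the result.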